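The source may report more compounds than this note shows. Statements on the series, on what has been measured and on what is new or still open speak of the compounds shown alone.

In a functional assay on the whole organism for inhibition, with Mythimna separata as the target, with a stated time of 5 days (a higher number here means that more compound is needed for the effect, a lower number that less compound is needed), three compounds on a shared core differ only in one group. Compound 1 `CC(C)(C)n1ncc(OCc2nnc(-c3ccc(Br)cc3)o2)c(Cl)c1=O` gives 21.4 ug/mL. Compound 2 `Cc1cc(C)cc(-c2nnc(COc3cnn(C(C)(C)C)c(=O)c3Cl)o2)c1` is reported only as a limit of the assay, > 300 ug/mL. Compound 3 `CC(C)(C)n1ncc(OCc2nnc(-c3cc(F)c(F)cc3F)o2)c(Cl)c1=O` gives 75.7 ug/mL, the higher of the two true numbers, and its nearest neighbour is compound 1.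

The next structure, compound 4 `CC(C)(C)n1ncc(OCc2nnc(-c3ccccc3)o2)c(Cl)c1=O`, follows from compound 3 by one change: phenyl in place of 2,4,5-trifluorophenyl on an aromatic carbon. Going by the values given here, no measured step makes this exact swap, but three steps at the same place bear on it. These are a 3.5-fold higher number from compound 1 to compound 3 (0.55 log units; beyond the scatter), which is modest, an at least 3.9-fold lower number from compound 2 to compound 3 (0.59 log units; beyond the scatter), which is at least modest, and an at least 14-fold higher number from compound 1 to compound 2 (1.14 log units; beyond the scatter), which is large. All three lie beyond the scatter, yet none shows what the unsubstituted phenyl does, so they give no firm direction.

In this assay, no step beyond the scatter is therefore expected, with only a slight lean towards a higher number. The estimated step is a 1.5-fold higher number from compound 3 to compound 4 (0.16 log units; within the scatter). The range stays wide because an at least 14-fold higher number from compound 1 to compound 2 (1.14 log units; beyond the scatter) shows how far this place can move the number. Compound 4 is expected at 110 ug/mL, with an estimated range from 35 ug/mL to 300 ug/mL.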

Compound 4, half-maximal effective concentration: 12.2 ug/mL
For compound 4 the middle estimate is 9.0-fold (0.96 log units) above the measured one; measured number outside the range, below it.
By their numbers in this assay, from the lowest: compounds 4 and 1 (each within the scatter of the next); then compound 3. At a limit, above all of these: compound 2.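

Compound 4 shows that this place on the five-membered ring needs no substituent on the phenyl for a number in the range of compound 1: with hydrogen in place of bromo, this assay gives a 1.8-fold lower number from compound 1 to compound 4 (0.24 log units; within the scatter). The bare phenyl also separates clearly from the fluorinated ring, with a 6.2-fold lower number from compound 3 to compound 4 (0.79 log units; beyond the scatter), so the earlier gap between the 4-bromophenyl and 2,4,5-trifluorophenyl groups now reads as a rise with the trifluorophenyl group, while bromo leaves no step beyond the scatter. Compound 2, with the 3,5-dimethylphenyl group, is reported only as a limit, so its comparison, an at least 24-fold lower number from compound 2 to compound 4 (1.39 log units; beyond the scatter), is a bound and not a measured size: the limit of > 300 ug/mL in this assay, at which 1 of the 4 values shown sits.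

Among the three substituted rings shown, none gives a number lower than the bare phenyl beyond the scatter, but three groups cannot show whether that holds for substituents in general. The compounds shown leave open what an amine or a carboxylic acid on the phenyl would do in this assay, and whether a longer chain could stand in place of the phenyl at this place.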